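The source may report more compounds than this note shows. Statements on the series, on what has been measured and on what is new or still open speak of the compounds shown alone.

Working notes on the series. Compound 1 `O=C(/C=C/c1ccccc1)c1ccc(N2CCN(S(=O)(=O)c3ccc(Cl)cc3)CC2)cc1` and compound 2 `O=C(/C=C/c1ccccc1)c1ccc(N2CCN(S(=O)(=O)c3ccc(OC(F)(F)F)cc3)CC2)cc1` share the core and differ only on the aromatic ring of the sulfonyl group. In a functional assay on the whole organism (strain Kunming) for inhibition, with Mus musculus as the target, with a stated time of 1 h, at a dose of 40 mg/kg by the oral route (a lower number here means less inhibition, a higher number more inhibition at the dose given (going by the name of the read-out)), compound 1 gives 46.8%, and compound 2 gives 47.4%. Within the data shown here, the step of a number 0.6 percentage points higher from compound 1 to compound 2 (within the scatter) is within the scatter, so compound 2 stands together with compound 1, the only other number in the set, without any order between them.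

Compound 3 `COc1ccc(S(=O)(=O)N2CCN(c3ccc(C(=O)/C=C/c4ccccc4)cc3)CC2)cc1OC` is the next member, with 3,4-dimethoxyphenyl in place of 4-(trifluoromethoxy)phenyl on a sulfonyl sulfur. Among the measured compounds shown here, the only measured step that bears on it is the one on the same aromatic ring, a number 0.6 percentage points higher from compound 1 to compound 2 (within the scatter), and that step stayed within the scatter. On this basis no step beyond the scatter is expected; the estimated change is a number 0.4 percentage points lower from compound 2 to compound 3 (within the scatter). Compound 3 is therefore estimated at 47%, with an expected range from 35% to 59%.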

Compound 3, a percentage reported as inhibition, in the whole organism at one dose (the size of the read-out at that dose, not a potency): 55.5%
Estimate against measurement, compound 3: 8.5 percentage points below; the measured number falls inside the stated range.
By their numbers in this assay, from the lowest: compounds 1, 2 and 3 (each within the scatter of the next).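

In this assay, putting 3,4-dimethoxyphenyl on a sulfonyl sulfur gives a number 8.1 percentage points higher from compound 2 to compound 3 (within the scatter) against 4-(trifluoromethoxy)phenyl and a number 8.7 percentage points higher from compound 1 to compound 3 (within the scatter) against 4-chlorophenyl. This position therefore accepts an aromatic group with two oxygen-linked methoxy groups, and 2 hydrogen-bond acceptors in place of 1, with no step beyond the scatter, so compounds 1, 2 and 3 stand together without an order. No measurement here offers an explanation for these numbers.

The compounds shown leave open whether an amine or a carboxylic acid on this aromatic ring would give a step beyond the scatter. They also leave open whether a simple butyl chain in place of the ring on the sulfonyl sulfur would keep the read-out within the same scatter.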